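Styryl-oxadiazole series: cytotoxicity notes toward compound 3

A few compounds are considered here, and "the series" means these few. Any claim that something is new, unique, unknown or untested is made for them only; others in the source may bear on it.

Measured so far:
compound 1 `COc1nc2ccccc2cc1/C=C/c1noc(-c2ccccc2)n1`: > 240000 nM
compound 2 `COc1nc2ccccc2cc1/C=C/c1noc(-c2cccc(C)c2)n1`: > 230000 nM

In an ADME assay on HepG2 cells (Homo sapiens) for cytotoxicity, read by sulforhodamine B assay, with a stated time of 48 h (a higher number here means that more compound is tolerated, a lower number that less compound is tolerated), compound 1 gives > 240000 nM, which is a limit of the assay and not a number. Compound 2 `COc1nc2ccccc2cc1/C=C/c1noc(-c2cccc(C)c2)n1` gives > 230000 nM in this assay, again a limit. The step that the two limits leave unreadable from compound 1 to compound 2 therefore cannot be sized; the limit of > 230000 nM in this assay, at which 1 of the 2 values shown sits, and the limit of > 240000 nM in this assay, at which 1 of the 2 values shown sits, show only where the two values sit. Compound 1 thus stands at a limit alone, with no numeric value in this assay.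

Compound 3 `COc1nc2ccccc2cc1/C=C/c1noc(-c2cccnc2)n1` differs from compound 1 by pyridin-3-yl in place of phenyl on an aromatic carbon. For the measured compounds named here, the only measured step is unreadable, so no measured step bears on this change and no step beyond the scatter is anticipated. Compound 3 is expected to give 250000 nM in this assay, within a range of 100000 nM to 600000 nM, most probably reported again as a limit. The step that the limit leaves unreadable from compound 1 to compound 3 is expected to stay within the scatter.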

Compound 3, half-maximal cytotoxic concentration: > 240000 nM
Compound 3 ended at the assay's limit; the forecaster's own chance of this, stated with the estimate: 80%; the middle value is on the limit's open side.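

For the compounds shown here, compound 1, compound 2 and compound 3 all stand at limits in this assay, so no step among them can be read. The compounds shown leave open where each true half-maximal cytotoxic concentration lies, and whether pyridin-3-yl in place of phenyl changes it at all.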